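The source may hold more compounds than are shown below. What is called first, only, known or untested is meant among the compounds shown, and "the series" means these compounds.

Measured so far:
- compound 1, `Cn1cnnc1SCC(=O)N/N=c1/scc(-c2ccc(F)cc2)n1-c1ccccc1`: 65 ug/mL
- compound 2, `Cn1nnnc1SCC(=O)N/N=c1/scc(-c2ccc(Br)cc2)n1-c1ccccc1`: 19.3 ug/mL

The assay is an ADME assay on NIH3T3 cells (Mus musculus) for cytotoxicity, read by MTT assay, with a stated time of 24 h; a higher number here means a weaker inhibitor, a lower number a stronger inhibitor. Compound 2 gives the lowest of the two numbers, so it is the stronger inhibitor of cell growth here; compound 1 gives a higher number, and that gap lies beyond the usual scatter of repeated measurements.

Compound 3, `Cn1nnnc1SCC(=O)N/N=c1/scc(-c2ccc(F)cc2)n1-c1ccccc1`, has not yet been measured. It differs from compound 2 in one place: fluoro in place of bromo on an aromatic carbon. Within the data shown here, no measured pair shows this same change on its own, so its effect can only be guessed. Compound 1, which also carries fluoro, gives the higher of the two numbers, but it differs from compound 3 in another part of the molecule as well, so it offers only a rough pointer.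

Compound 3 is expected to sit between the two measured values, and the expected step of a 1.8-fold higher number from compound 2 to compound 3 (0.26 log units; within the scatter) would be a modest rise, at the edge of the scatter. The estimate for compound 3 in this assay is 35 ug/mL, with a likely range from 15 ug/mL to 80 ug/mL.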

Compound 3, half-maximal inhibitory concentration: 113 ug/mL
Estimate against measurement, compound 3: 3.2-fold (0.51 log units) below, and the stated range ends below it.
By their numbers in this assay, from the lowest: compound 2; then compounds 1 and 3 (each within the scatter of the next).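

In this assay the change from 4-bromophenyl to 4-fluorophenyl gives a 5.9-fold higher number from compound 2 to compound 3 (0.77 log units; beyond the scatter) and so shows that swapping this one atom, on an aromatic carbon para to a large group, is enough to move the number beyond the scatter. With fluoro held fixed, putting 1-methyl-1H-tetrazol-5-yl in place of 4-methyl-4H-1,2,4-triazol-3-yl on the sulfur gives a 1.7-fold higher number from compound 1 to compound 3 (0.24 log units; within the scatter) and leaves the two compounds within the scatter of each other, so the halogen swap shows a clear effect here while this ring swap does not. No measured evidence is available to explain the effect of the halogen swap.

On these data alone, how chloro or a methoxy group would read at this place remains open. As far as these compounds go, it is also open whether the ring swap on the sulfur would read the same with bromo on the phenyl ring.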